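The source may report more compounds than this note shows. Statements on the series, on what has been measured and on what is new or still open speak of the compounds shown alone.

Measured compounds:
compound 1 `CCN(CC)c1ccc2cc(C(=O)c3ccc(N4CCN(C(=O)CN5CCN(S(=O)(=O)c6ccc(F)cc6)CC5)CC4)cc3)oc2c1`: 33200 nM
compound 2 `C#CCN1CCN(CC(=O)N2CCN(c3ccc(C(=O)c4cc5ccc(N(CC)CC)cc5o4)cc3)CC2)CC1`: a limit, > 40000 nM

In a functional assay on A549 cells (Homo sapiens) for cytotoxicity, read by MTT assay, with a stated time of 48 h (a higher number here means a weaker inhibitor, a lower number a stronger inhibitor), compound 1 gives 33200 nM. For compound 2 the assay reports only a limit, > 40000 nM. The step of an at least 1.2-fold higher number from compound 1 to compound 2 (0.08 log units; that floor lies within the scatter), propargyl in place of (4-fluorophenyl)sulfonyl on an amine nitrogen in a ring, therefore rests on the limit of > 40000 nM in this assay, at which 1 of the 2 values shown sits, and cannot be sized further. Compound 3 `CCOC(=O)CN1CCN(CC(=O)N2CCN(c3ccc(C(=O)c4cc5ccc(N(CC)CC)cc5o4)cc3)CC2)CC1` differs from compound 2 by ethoxycarbonyl in place of ethynyl on a saturated chain carbon bound to an amine nitrogen in a ring. Within the data shown here, no measured step touches that position, and compound 2 itself offers only a limit. The step that the limit leaves unreadable from compound 2 to compound 3 is expected to stay within the scatter. Compound 3 is estimated at 45000 nM, between 15000 nM and 150000 nM.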

Compound 3, half-maximal inhibitory concentration: > 40000 nM
Compound 3 gave a limit, no number; the forecaster's own chance of this, stated with the estimate: 60%; the middle value is on the limit's open side.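

In this assay, a second group on this amine nitrogen in a ring, (ethoxycarbonyl)methyl, again gives only a limit, as propargyl did. Set against the (4-fluorophenyl)sulfonyl group of compound 1, this change gives an at least 1.2-fold higher number from compound 1 to compound 3 (0.08 log units; that floor lies within the scatter), so the floor does not separate the two compounds. The step from compound 2 to compound 3 cannot be read: the limit of > 40000 nM in this assay, at which 2 of the 3 values shown sit.

Going by these compounds, whether a carboxylic acid or a longer chain at this position would give a number rather than a limit remains open. So does whether any group here can move the value beyond the scatter.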